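The source may hold more compounds than are shown below. What is called first, only, known or untested is meant among the compounds shown, and "the series" means these compounds.

Measured so far:
compound 1, `O=C1CSC(c2c(Cl)cccc2Cl)N1CCN1CCCCC1`, 11%
compound 2, `Cc1ccc(C2SCC(=O)N2CCN2CCCCC2)cc1`, 17%

Both numbers come from an ADME assay on Vero cells (Chlorocebus sabaeus) for cytotoxicity, read by neutral red uptake, tested at 787 ug/mL; a higher number here means a weaker effect of the compound at the concentration tested, a lower number a stronger effect. On the numbers shown, compound 2 holds the top value of the two, but its distance from compound 1 is within the scatter, so the two compounds cannot be told apart in this assay. Going by the values given here, no step between compounds differing in one place is available.

Compound 3, `O=C1CSC(c2ccccc2Cl)N1CCN1CCCCC1`, is not yet measured in this assay. Its difference from compound 2 is 2-chlorophenyl in place of 4-methylphenyl on a saturated ring carbon. Both phenyl variants measured so far, the 4-methylphenyl of compound 2 and the 2,6-dichlorophenyl of compound 1, give low numbers of the same size, so no step beyond the scatter is expected for a number 4 percentage points lower from compound 2 to compound 3 (within the scatter). For compound 3 the expected value in this assay is 13%, with a range from 4% to 25%.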

Compound 3, a percentage reported as activity, at one concentration (the size of the read-out at that concentration, not a potency): 38%
Beside the measured number, compound 3's estimate is 25 percentage points below it; the measured number lies above the stated range.
By their numbers in this assay, from the lowest: compounds 1 and 2 (each within the scatter of the next); then compound 3.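

In this assay, the group on the saturated ring carbon does matter: 2-chlorophenyl in place of 4-methylphenyl gives a number 21 percentage points higher from compound 2 to compound 3 (beyond the scatter), and hydrogen in place of chloro on an aromatic carbon gives a number 27 percentage points higher from compound 1 to compound 3 (beyond the scatter). Compounds 1 and 2 lie within the scatter of each other and did not reveal this sensitivity, whereas compound 3 shows a weaker effect at the concentration tested than either of them. No available measurement accounts for these steps.

Still open, going by these compounds, is whether the step from compound 2 follows from the chloro itself or from where the substituent sits, which 4-chlorophenyl and 2-methylphenyl would separate. Unsubstituted phenyl is also absent from the compounds shown, so the read-out without any substituent remains unknown.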